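The source may report more compounds than this note shows. Statements on the series, on what has been measured and on what is new or still open speak of the compounds shown alone.

Compound 1 `Cn1cc(C2=C(c3nn(CCn4ccnc4)c4ncccc34)C(=O)NC2=O)c2ccccc21` carries an imidazole on a two-carbon chain attached at an aromatic nitrogen of the shared core. In a functional assay on K562 cells (Homo sapiens) for antiproliferative activity, read by MTT assay, with a stated time of 48 h (a lower number here means a stronger inhibitor, a higher number a weaker inhibitor), compound 1 reaches only the assay limit of > 100000 nM. Compound 2 `Cn1cc(C2=C(c3n[nH]c4ncccc34)C(=O)N(c3cccc4ccccc34)C2=O)c2ccccc21` likewise gives only the limit of > 100000 nM in this assay. Within the data shown here, compound 3 `Cn1cc(C2=C(c3nn(CCCn4cccc4)c4ncccc34)C(=O)N(c3ccccc3)C2=O)c2ccccc21` is the one compound with a number, 36600 nM in this assay. Compound 1 therefore stands at the limit of > 100000 nM in this assay, at which 2 of the 3 values shown sit. Compound 4 `Cn1cc(C2=C(c3nn(CCCCn4ccnc4)c4ncccc34)C(=O)NC2=O)c2ccccc21` differs from compound 1 by 2-(1H-imidazol-1-yl)ethyl in place of 1H-imidazol-1-yl on a saturated chain carbon, two bonds along the chain from an aromatic nitrogen. Among the measured compounds shown here, with no measured step of this kind to lean on, and compound 1 sitting at the limit > 100000 nM, the step from compound 1 to compound 4 is expected to be small or none beyond the scatter, a number no higher from compound 1 to compound 4 (the limit leaves the size open). Compound 4 is expected to give about 100000 nM in this assay, within 30000 nM to 300000 nM.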

Compound 4, half-maximal inhibitory concentration: 31800 nM
Compound 4: the middle estimate sits 3.1-fold (0.50 log units) above what was measured, and the stated range covers the measured number.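

On a saturated chain carbon, two bonds along the chain from an aromatic nitrogen, 2-(1H-imidazol-1-yl)ethyl in place of 1H-imidazol-1-yl gives an at least 3.1-fold lower number from compound 1 to compound 4 (0.49 log units; beyond the scatter) in this assay. Among these compounds, this is the first measured step at this place, and it shows that the number responds to this change of the chain. The size of the step stays open, as the starting value of compound 1 is a limit: the limit of > 100000 nM in this assay, at which 2 of the 4 values shown sit.

Going by these compounds, whether a longer chain would lower the number further remains open, as does the effect of an amine in place of the 1H-imidazol-1-yl group.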